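Chain length on a piperazine-bearing core in the electroshock model

The source may hold more compounds than are shown below. What is called first, only, known or untested is meant among the compounds shown, and "the series" means these compounds.

Compound 1 `CCCc1cccc(N2CCNCC2)n1`: 10 mg/kg
Compound 2 `CCCCCCCc1cccc(N2CCCCC2)n1`: > 300 mg/kg
Compound 3 `CCCCCCCc1cccc(N2CCCNCC2)n1`: 30 mg/kg

In a functional assay on the whole organism with Mus musculus as the target, in the maximal electroshock model, with a stated time of 120 min (on this read-out higher numbers stand for an effect only at larger amounts of compound and lower numbers for an effect already at smaller amounts), compound 1 gives 10 mg/kg, the lowest of the two numbers shown. Compound 3 stands nearest with 30 mg/kg, a gap beyond the usual scatter. For compound 2 the assay reports only a limit, > 300 mg/kg, and no number (the limit of > 300 mg/kg in this assay, at which 1 of the 3 values shown sits).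

Compound 4 `CCCCCCCCc1cccc(N2CCNCC2)n1` differs from compound 1 by pentyl in place of hydrogen on a saturated chain carbon, three bonds along the chain from an aromatic carbon. Within the data shown here, no pair measured so far differs in one place, so the size of this step rests on expectation alone. Compound 3 with 30 mg/kg carries a long chain and still gives a number, so a modest rise in the minimum effective dose is expected, a 3.0-fold higher number from compound 1 to compound 4 (0.48 log units; beyond the scatter). Compound 4 is estimated at 30 mg/kg, within 10 mg/kg to 100 mg/kg.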

Compound 4, minimum effective dose: 10 mg/kg
Compound 4: the middle estimate sits 3.0-fold (0.48 log units) above what was measured; the measured number falls inside the stated range.
By their numbers in this assay, from the lowest: compounds 1 and 4 (each within the scatter of the next); then compound 3. At a limit, above all of these: compound 2.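

Among these compounds, the only pair differing in one place shows what this position tolerates: in this assay, pentyl in place of hydrogen on a saturated chain carbon, three bonds along the chain from an aromatic carbon, gives no change at the digits printed from compound 1 to compound 4 (within the scatter). The minimum effective dose of the shared core therefore does not follow this lengthening of the chain. No measurement shown gives a reason for this. Still open, from the compounds shown here alone, is whether a longer chain would leave the dose as unchanged, and whether an amine or a carboxylic acid at the end of the chain would do the same.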